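The source may hold more compounds than are shown below. What is called first, only, known or untested is meant among the compounds shown, and "the series" means these compounds.

Three compounds share one core. In an assay on HEK293 cells for antagonist activity at P2X purinoceptor 7 (Homo sapiens), read by fluorescence, with a stated time of 2 h (on this read-out lower numbers stand for stronger inhibition and higher numbers for weaker inhibition), compound 1 `N#Cc1cccc(S(=O)(=O)Oc2ccc(-c3cncn3C3CCN(C(=O)c4ccc([N+](=O)[O-])cc4)CC3)cc2)c1` gives 45 nM, compound 2 `CN(C)c1ccc(C(=O)N2CCC(n3cncc3-c3ccc(OS(=O)(=O)c4cccc(C#N)c4)cc3)CC2)cc1` gives 32 nM, and compound 3 `COc1ccc(C(=O)N2CCC(n3cncc3-c3ccc(OS(=O)(=O)c4cccc(C#N)c4)cc3)CC2)cc1` gives 312 nM, the highest number of the three. The steps of a 6.9-fold higher number from compound 1 to compound 3 (0.84 log units; beyond the scatter) and a 9.8-fold higher number from compound 2 to compound 3 (0.99 log units; beyond the scatter) set compound 3 apart, whereas a 1.4-fold lower number from compound 1 to compound 2 (0.15 log units; within the scatter) stays within the scatter. Compound 4 `CNC(=O)c1cccc(S(=O)(=O)Oc2ccc(-c3cncn3C3CCN(C(=O)c4ccc(OC)cc4)CC3)cc2)c1` keeps the methoxy group of compound 3 and alters a different part of the molecule: methylcarbamoyl in place of cyano on an aromatic carbon. Among the measured compounds shown here, none of the measured steps touches this group; each of them exchanges only the substituent varied between compound 1, compound 2 and compound 3, so no measured step bears on the change. The expectation rests on compound 3 alone and carries wide bounds. The step of a 1.0-fold lower number from compound 3 to compound 4 (0.02 log units; within the scatter) is expected to stay within the scatter. Compound 4 is estimated at 300 nM, between 80 nM and 1200 nM.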

Compound 4, half-maximal inhibitory concentration: 159 nM
Compound 4: middle estimate off by 1.9-fold (0.28 log units), on the high side, within the range that was stated.
By their numbers in this assay, from the lowest: compounds 2 and 1 (each within the scatter of the next); then compounds 4 and 3 (each within the scatter of the next).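

Among the compounds shown here, at the cyano position, a 2.0-fold lower number from compound 3 to compound 4 (0.29 log units; within the scatter) in this assay, the first reading for any change on this ring. With methoxy on the benzoyl ring, methylcarbamoyl therefore sits in place of cyano without a step beyond the scatter, and the larger group with its amide hydrogen leaves the number in the range of compound 3. Going by these compounds, whether this holds with the nitro group of compound 1 or the dimethylamino group of compound 2 stays open, as does the outcome with a carboxylic acid or a longer chain on the amide nitrogen. No supporting data bear on this result.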